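This account rests on a few compounds, and the source may have more. Where it says the series, first, only, none or still open, it means among the compounds named here.

Measured in a functional assay on MCF7 cells (Homo sapiens) for antiproliferative activity, read by MTT assay, with a stated time of 48 h; a higher number here means a weaker inhibitor, a lower number a stronger inhibitor:

- compound 1 `COC(=O)[C@H](CC(C)C)NC(=O)c1ccc(Oc2nc3ccccc3nc2C)cc1` gives 25500 nM
- compound 2 `CCCCCCCCCCCCNc1nc2ccccc2nc1Oc1ccc(C(=O)N[C@H](C(=O)OC)[C@H](C)CC)cc1` gives 43300 nM
- compound 3 `COC(=O)[C@H](CC(C)C)NC(=O)c1ccc(Oc2nc3ccccc3nc2NC(C)(C)C)cc1` gives > 50000 nM

For compound 3 the reading of > 50000 nM is a limit of the assay and not a number. It stands at the limit of > 50000 nM in this assay, at which 1 of the 3 values shown sits.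

Compound 4 `CC[C@@H](C)[C@H](NC(=O)c1ccc(Oc2nc3ccccc3nc2NC(C)(C)C)cc1)C(=O)O` differs from compound 3 on an amide-type nitrogen, where 1-carboxy-2-methylbutyl takes the place of 1-(methoxycarbonyl)-3-methylbutyl: 1-carboxy-2-methylbutyl in place of 1-(methoxycarbonyl)-3-methylbutyl on an amide-type nitrogen.

Among the compounds with values here, the one measured step in this set, an at least 1.9-fold higher number from compound 1 to compound 3 (0.29 log units; that floor lies within the scatter), comes from a different change, (tert-butyl)amino in place of methyl on an aromatic carbon. Within the data shown here, no measured step changes the group on the amide-type nitrogen, so it gives only weak guidance here. In this assay no step beyond the scatter is therefore expected, and another reading at the limit is the likeliest outcome.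

The step expected is a step that the limit leaves unreadable from compound 3 to compound 4.

For compound 4 the estimated value is 60000 nM, with an expected range from 25000 nM to 150000 nM.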

Compound 4, half-maximal inhibitory concentration: 11400 nM
For compound 4 the middle estimate is 5.3-fold (0.72 log units) above the measured one; measured number outside the range, below it.
By their numbers in this assay, from the lowest: compound 4; then compounds 1 and 2 (each within the scatter of the next). At a limit, above all of these: compound 3.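

Within the data shown here, the group on the amide-type nitrogen matters in this assay: with the (tert-butyl)amino group kept, 1-carboxy-2-methylbutyl in place of 1-(methoxycarbonyl)-3-methylbutyl gives an at least 4.3-fold lower number from compound 3 to compound 4 (0.64 log units; beyond the scatter), the first step in this set that lies beyond the scatter. Among the compounds shown, compound 4 is the first carrying (tert-butyl)amino to give a true number, 11400 nM. Compound 3 reads as a limit and not a number, so the real step may be larger: the limit of > 50000 nM in this assay, at which 1 of the 4 values shown sits.

This single change swaps the methyl ester for a free carboxylic acid and also moves the methyl on the butyl chain, and the compounds shown cannot say how much of the step belongs to each. Also open, from the compounds shown here alone, is how a primary amide or a longer chain at this place would read.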